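Extending the side chain of compound 1 toward a hydroxypiperidine

A few compounds are considered here, and "the series" means these few. Any claim that something is new, unique, unknown or untested is made for them only; others in the source may bear on it.

Compound 1 `O=C1c2c[n+]([O-])c3ccccc3c2C(=O)c2c1c1ccccc1n2CCN1CCCC1` is the reference point. In a functional assay on A-375 cells (Homo sapiens) for cytotoxicity, read by MTT assay, with a stated time of 72 h (a lower number here means a stronger inhibitor, a higher number a weaker inhibitor), compound 1 gives 430 nM, which lies within the scatter of both companions: compound 2 `CC1(C)OC[C@@H](Cn2cc(Cn3c4c(c5ccccc53)C(=O)c3c[n+]([O-])c5ccccc5c3C4=O)nn2)O1` gives 450 nM, and compound 3 `O=C1c2c[n+]([O-])c3ccccc3c2C(=O)c2c1c1ccccc1n2Cc1cn([C@@H]2O[C@H](CO)[C@@H](O)[C@H](O)[C@H]2O)nn1` gives 230 nM. Among the measured compounds shown here, the single measured step, a 2.0-fold lower number from compound 2 to compound 3 (0.29 log units; within the scatter), concerns the group on the triazole and leaves the shared core untouched. Compound 4 `O=C1c2c[n+]([O-])c3ccccc3c2C(=O)c2c1c1ccccc1n2CCCN1CCC(O)CC1` differs from compound 1 only in the chain on the indole nitrogen: (4-hydroxypiperidin-1-yl)methyl in place of pyrrolidin-1-yl on a saturated chain carbon, two bonds along the chain from an aromatic nitrogen. For the measured compounds named here, no measured step touches this chain, so nothing here points to a change beyond the scatter. Compound 4 is therefore expected to give 450 nM, between 200 nM and 1000 nM, a step of a 1.0-fold higher number from compound 1 to compound 4 (0.02 log units; within the scatter).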

Compound 4, half-maximal inhibitory concentration: 240 nM
The estimate for compound 4 lay 1.9-fold (0.27 log units) above the measured number; measured number inside the range.
By their numbers in this assay, from the lowest: compounds 3, 4, 1 and 2 (each within the scatter of the next).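

Among the compounds shown here, the only measured step on this chain, in this assay, replaces 2-(pyrrolidin-1-yl)ethyl with 3-(4-hydroxypiperidin-1-yl)propyl and reads a 1.8-fold lower number from compound 1 to compound 4 (0.25 log units; within the scatter). At this position, then, the longer chain, the six-membered ring and the hydroxyl together leave the number within the scatter. No available evidence bears on why this is so. On these data alone, the chain and the ring change together here, so their separate contributions remain open. Also open, as far as these compounds go, is how a 3-(pyrrolidin-1-yl)propyl chain, or a carboxylic acid at the end of the chain, would read.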